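Thiazole in place of cyanophenyl on a piperazine nitrogen

A few compounds are considered here, and "the series" means these few. Any claim that something is new, unique, unknown or untested is made for them only; others in the source may bear on it.

Compound 1, `O/N=C(/CCN1CCN(c2ncccn2)CC1)c1ccccc1`, gives 69 nM in a functional assay on HEK293 cells with D(4) dopamine receptor (Homo sapiens) as the target, read by FLIPR; on this read-out higher numbers stand for an effect only at larger amounts of compound and lower numbers for an effect already at smaller amounts.
Compound 2, `CCO/N=C(\CCN1CCN(c2ccccc2C#N)CC1)c1ccccc1`, gives 48.7 nM in this assay.

Of the compounds shown here, two have been measured. Of the pair, compound 2 and compound 1 give values that lie within the usual scatter of each other, so the two numbers cannot be told apart with confidence. The next compound, compound 3, `CCO/N=C(\CCN1CCN(c2nccs2)CC1)c1ccccc1`, keeps the ethyl oxime of compound 2 and differs from it in one place: 1,3-thiazol-2-yl in place of 2-cyanophenyl on an amine nitrogen in a ring. Among the compounds with values here, no step between measured compounds isolates this kind of exchange, so the expected size must rest on the whole set. Compound 1, which also carries an aromatic ring with two nitrogen atoms on that amine nitrogen, gives 69 nM, and an exchange of this kind is expected to give no more than a modest step in this assay, if any beyond the scatter. Compound 3 is therefore estimated at 80 nM, with a range from 25 nM to 250 nM, which means an expected step of a 1.6-fold higher number from compound 2 to compound 3 (0.22 log units; within the scatter).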

Compound 3, half-maximal effective concentration: 81.8 nM
Beside the measured number, compound 3's estimate is 1.0-fold (0.01 log units) below it, within the range that was stated.
By their numbers in this assay, from the lowest: compounds 2, 1 and 3 (each within the scatter of the next).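

In this assay, within the data shown here, the exchange of 2-cyanophenyl for 1,3-thiazol-2-yl on the amine nitrogen in the ring gives a 1.7-fold higher number from compound 2 to compound 3 (0.23 log units; within the scatter), the first step in this set that isolates this place with the ethyl oxime held constant. The two compounds cannot be told apart here, so this place accepts a five-membered aromatic ring with 2 hetero atoms as readily as a six-membered aromatic ring of carbon only, and the nitrile is not needed for a value in this range. Nothing available explains why the exchange leaves the read-out within the scatter.

From the compounds shown here alone, it remains open whether an unsubstituted phenyl, a pyridin-2-yl or a 1,3-thiazol-2-yl bearing a methyl group would fit this place equally well. Also open, going by these compounds, is how a longer chain on the oxime oxygen would fare with the thiazole in place.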